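Adding bromo to compound 2: expectation for compound 3

The compounds below may be only part of what the source reports. "The series", "measured", "known", "first", "only" and "open" are said of these compounds alone.

Two compounds of the series have numbers in an assay on isolated protein for inhibition of protein tyrosine phosphatase type IVA 3 (Homo sapiens), tested at 5 ug/mL; a higher number here means more inhibition at the concentration tested (going by the name of the read-out), a lower number less inhibition. Compound 1 `O=C1NC(=O)/C(=C/C=C/c2ccccc2OCc2ccccc2Br)S1` gives 22.5%. Compound 2 `O=C1NC(=S)S/C1=C\C=C\c1ccccc1OCc1ccccc1` gives 49.5%, the highest of the two values; the gap to compound 1 lies beyond the usual scatter, but compound 1 and compound 2 differ in more than one place, so nothing here is tied to a single change. Compound 3 `O=C1NC(=S)S/C1=C\C=C\c1ccccc1OCc1ccccc1Br` is the next compound and has not yet been measured. It differs from compound 2 in one place: bromo in place of hydrogen on an aromatic carbon. For the measured compounds named here, no pair measured so far differs in this change alone, so its effect is unknown. The expected step is a number 4.5 percentage points lower from compound 2 to compound 3 (within the scatter), not beyond the scatter in either direction. Compound 3 is accordingly estimated to give 45% in this assay, with a range from 25% to 65%.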

Compound 3, a percentage reported as inhibition, at one concentration (the size of the read-out at that concentration, not a potency): 63.1%
Compound 3: the middle estimate sits 18.1 percentage points below what was measured; measured number inside the range.
By their numbers in this assay, from the lowest: compound 1; then compound 2; then compound 3.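

In this assay, for the compounds shown here, the aromatic carbon ortho to a large group accepts more than hydrogen: going from benzyl to 2-bromobenzyl gives a number 13.6 percentage points higher from compound 2 to compound 3 (beyond the scatter), the first reading of a single change at this position. With 2-bromobenzyl held constant, the group of 8 heavy atoms with 1 oxygen and 2 sulfur, in place of the group with 2 oxygen and 1 sulfur, gives a number 40.6 percentage points higher from compound 1 to compound 3 (beyond the scatter), the larger of the two steps. No measurement at hand accounts for either step.

As far as these compounds go, whether chloro or methoxy on the same carbon would match bromo remains open, as does the effect of bromo on another carbon of that ring. Also open, from the compounds shown here alone, is whether the bromo step holds with the group containing 2 oxygen and 1 sulfur.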